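Sulfonyl aryl swap on a shared indole-type core

The source may hold more compounds than are shown below. What is called first, only, known or untested is meant among the compounds shown, and "the series" means these compounds.

Compound 1, `COc1cccc(C(=O)N(C)c2ccc3[nH]c(-c4n[nH]c5ccccc45)cc3n2)c1`: 14900 nM
Compound 2, `CN(c1ccc2[nH]c(-c3n[nH]c4ccccc34)cc2n1)S(=O)(=O)c1ccccc1`: 14000 nM
Compound 3, `COc1ccc(S(=O)(=O)N(C)c2ccc3[nH]c(-c4n[nH]c5ccccc45)cc3n2)cc1OC`: > 50000 nM

In a functional assay on A549 cells (Homo sapiens) for antiproliferative activity, read by MTT assay, with a stated time of 72 h (a higher number here means a weaker inhibitor, a lower number a stronger inhibitor), compound 1 gives 14900 nM and compound 2 gives 14000 nM, a pair whose step a 1.1-fold lower number from compound 1 to compound 2 (0.03 log units; within the scatter) lies within the scatter. For compound 3 the assay records only a limit, > 50000 nM, as noted in the limit of > 50000 nM in this assay, at which 1 of the 3 values shown sits. The step of an at least 3.5-fold higher number from compound 2 to compound 3 (0.55 log units; beyond the scatter) is therefore at least modest. Compound 4, `CN(c1ccc2[nH]c(-c3n[nH]c4ccccc34)cc2n1)S(=O)(=O)c1ccc(OC(F)(F)F)cc1`, differs from compound 3 by 4-(trifluoromethoxy)phenyl in place of 3,4-dimethoxyphenyl on a sulfonyl sulfur. Among the compounds with values here, the only measured step that bears on the sulfonyl aryl group is that from compound 2 to compound 3, which shows that decorating the phenyl weakened inhibition; nothing measured covers a trifluoromethoxy group. Compound 4 is therefore expected to sit between compound 2 and the limit, with a step of an at least 1.6-fold lower number from compound 3 to compound 4 (0.22 log units; that floor lies within the scatter) that is uncertain in direction, and an estimate of 30000 nM ranging from 10000 nM to 80000 nM.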

Compound 4, half-maximal inhibitory concentration: 8000 nM
Compound 4: the middle estimate sits 3.8-fold (0.57 log units) above what was measured; measured number below the stated range.
By their numbers in this assay, from the lowest: compounds 4, 2 and 1 (each within the scatter of the next). At a limit, above all of these: compound 3.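

Moving to 4-(trifluoromethoxy)phenyl on the sulfonyl sulfur gives an at least 6.2-fold lower number from compound 3 to compound 4 (0.79 log units; beyond the scatter) and shows that this position can carry a substituted phenyl without the loss seen with 3,4-dimethoxyphenyl. Trifluoromethoxy in place of hydrogen on the phenyl gives a 1.8-fold lower number from compound 2 to compound 4 (0.24 log units; within the scatter) and so cannot be told apart from the unsubstituted phenyl. Compound 3 stands only at a limit: the limit of > 50000 nM in this assay, at which 1 of the 4 values shown sits.

In this assay the compounds shown leave open how a phenyl carrying an amine or a carboxylic acid would read. They also leave open whether any group at this position can bring a step beyond the scatter from compound 2.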